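Lengthening the Ketone Chain in a Glutamate Receptor Modulator

The compounds below may be only part of what the source reports. "The series", "measured", "known", "first", "only" and "open" are said of these compounds alone.

Compound 2 `CCC(=O)c1ccc(OCCCCOc2cc(C(=O)O)ccc2OC)c(C)c1O` was tested in an assay on HEK293 cells for positive allosteric modulation of metabotropic glutamate receptor 2 (Rattus norvegicus), read by thallium flux, with a stated time of 2.5 min (on this read-out lower numbers stand for an effect already at smaller amounts and higher numbers for an effect only at larger amounts of compound), and gives 162 nM. Compound 1 `Cc1c(OCCCCOc2ccc(C(=O)C(C)C)c(O)c2C)cccc1C(=O)O` gives 149 nM in this assay; compound 2 stands highest of the two numbers, yet the two values lie within the usual scatter of each other. Compound 3 `CCCC(=O)c1ccc(OCCCCOc2cc(C(=O)O)ccc2OC)c(C)c1O` differs from compound 2 by methyl in place of hydrogen on a saturated chain carbon, two bonds along the chain from a carbonyl carbon. Among the compounds with values here, no pair of measured compounds isolates this change, so nothing measured here points in either direction. The expected step is a 1.0-fold lower number from compound 2 to compound 3 (0.01 log units; within the scatter), a shift not beyond the scatter. Compound 3 is therefore estimated at 160 nM, with a range from 60 nM to 450 nM.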

Compound 3, half-maximal effective concentration: 103 nM
Beside the measured number, compound 3's estimate is 1.6-fold (0.19 log units) above it; the measured number falls inside the stated range.
By their numbers in this assay, from the lowest: compounds 3, 1 and 2 (each within the scatter of the next).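

In this assay, the methyl that turns propanoyl into propylcarbonyl gives a 1.6-fold lower number from compound 2 to compound 3 (0.20 log units; within the scatter). Within the data shown here, this is the first measured change at this position, and it shows that the saturated chain carbon two bonds along from the carbonyl carbon can carry one more methyl with no shift beyond the scatter. Nothing available here explains the numbers. Going by these compounds, what a longer chain, such as pentanoyl, would do at this position remains open. So does the effect of an amine or a carboxylic acid on this chain.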